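This account rests on a few compounds, and the source may have more. Where it says the series, first, only, none or still open, it means among the compounds named here.

Measured so far in an assay on membranes from brain for displacement of a labelled ligand from Sigma non-opioid intracellular receptor 1 (Cavia porcellus), read by scintillation counting, with a stated time of 1 h; on this read-out lower numbers stand for stronger inhibition and higher numbers for weaker inhibition:
- compound 1, `Cn1nc(CN2CCCC2)nc1-c1ccc(C(C)(C)C)cc1`: 2.7 nM
- compound 2, `Cn1nc(CN2CCN(c3ccccc3)CC2)nc1-c1ccc(C(C)(C)C)cc1`: 14 nM

Of these two numbers, compound 2 has the higher one, a gap to compound 1 that lies beyond the usual scatter of such measurements. For the measured compounds named here, the two compounds share a core and differ in the amine attached through the methylene; no single-point step between them is laid out, so only their two values are compared here.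

Compound 3, `CN1CCN(Cc2nc(-c3ccc(C(C)(C)C)cc3)n(C)n2)CC1`, keeps the six-membered ring with two nitrogens of compound 2 and changes only what sits on its far nitrogen: methyl in place of phenyl on an amine nitrogen in a ring. Whether this helps or hurts cannot be read off the two measured compounds, since neither of them carries a methyl at that position. The likeliest outcome is a step from compound 2 to compound 3 that stays within the scatter or leans slightly toward a higher number; the estimated step is a 1.4-fold higher number from compound 2 to compound 3 (0.15 log units; within the scatter). Compound 3 is therefore expected to give about 20 nM in this assay, with a plausible range from 5 nM to 80 nM.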

Compound 3, inhibition constant: 131 nM
Beside the measured number, compound 3's estimate is 6.6-fold (0.82 log units) below it; measured number outside the range, above it.
By their numbers in this assay, from the lowest: compound 1; then compound 2; then compound 3.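

In this assay, the group on the amine nitrogen in the six-membered non-aromatic ring proves to matter: methyl in place of phenyl gives a 9.4-fold higher number from compound 2 to compound 3 (0.97 log units; beyond the scatter), so this position does not accept the two groups alike, and of the pair, phenyl goes with the lower number. The change of the whole amine tells the same story from another side, since 4-methylpiperazin-1-yl in place of pyrrolidin-1-yl on the saturated chain carbon gives a 49-fold higher number from compound 1 to compound 3 (1.69 log units; beyond the scatter) and thus a much larger distance than the earlier pair of compounds displayed. Nothing available explains why either step is so large.

The compounds shown leave open whether the lower number of compound 2 depends on an aromatic ring at this nitrogen or on the size of the group alone, which a benzyl group, a cyclohexyl group or a longer chain such as n-butyl would help to separate. They also leave open how a bare hydrogen on that nitrogen would compare with methyl and phenyl, and whether a fluorine or methoxy group on the phenyl ring would shift the number of compound 2.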